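The source may hold more compounds than are shown below. What is called first, only, known or untested is meant among the compounds shown, and "the series" means these compounds.

Compound 1, whose structure is `C=C1C(=O)[C@]23C[C@@]1(O)CC[C@H]2[C@@]12C=CC(=O)[C@](C)(C(=O)O1)[C@H]2[C@@H]3C(=O)OC`, is the reference point of this small set. In a functional assay on HT-29 cells (Homo sapiens) for cytotoxicity, read by MTT assay (a higher number here means a weaker inhibitor, a lower number a stronger inhibitor), compound 1 gives 65700 nM. Compound 2, with the structure `C=C1C(=O)[C@]23C[C@@]1(O)CC[C@H]2[C@@]12C=CC(=O)[C@](C)(C(=O)O1)[C@H]2[C@@H]3C(=O)OCc1ccccc1`, differs from compound 1 by phenyl in place of hydrogen on a saturated chain carbon bound to an oxygen next to a carbonyl group; in this assay compound 2 gives 83300 nM, and the change made a 1.3-fold higher number from compound 1 to compound 2 (0.10 log units; within the scatter). Compound 3, with the structure `C=C1C(=O)[C@]23C[C@@]1(OCC)CC[C@H]2[C@@]12C=CC(=O)[C@](C)(C(=O)O1)[C@H]2[C@@H]3C(=O)OC`, differs from compound 1 by ethyl in place of hydrogen on an oxygen on a saturated carbon; in this assay compound 3 gives 34100 nM, a step of a 1.9-fold lower number from compound 1 to compound 3 (0.28 log units; within the scatter). The values of compound 3 and compound 2 lie further apart than those of compound 3 and compound 1, but no more can be read from those two numbers alone.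

Compound 4, with the structure `C=C1C(=O)[C@]23C[C@@]1(OCC)CC[C@H]2[C@@]12C=CC(=O)[C@](C)(C(=O)O1)[C@H]2[C@@H]3C(=O)OCc1ccccc1`, has not yet been measured. It differs from compound 3 by phenyl in place of hydrogen on a saturated chain carbon bound to an oxygen next to a carbonyl group. This is the same change that separates compound 2 from compound 1, where it made a 1.3-fold higher number from compound 1 to compound 2 (0.10 log units; within the scatter); the cores on which it is made differ by ethyl in place of hydrogen on an oxygen on a saturated carbon. Because the earlier instance of this change gave a 1.3-fold higher number from compound 1 to compound 2 (0.10 log units; within the scatter), the step from compound 3 to compound 4 is expected to be of similar size, estimated as a 1.3-fold higher number from compound 3 to compound 4 (0.11 log units; within the scatter). On that basis the estimate for compound 4 in this assay is 44000 nM, expected to fall between 20000 nM and 100000 nM.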

Compound 4, half-maximal inhibitory concentration: 23300 nM
Compound 4: middle estimate off by 1.9-fold (0.28 log units), on the high side; measured number inside the range.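

In this assay, going by these compounds alone, phenyl in place of hydrogen on a saturated chain carbon bound to an oxygen next to a carbonyl group, which turns methoxycarbonyl into benzyloxycarbonyl, gave a 1.5-fold lower number from compound 3 to compound 4 (0.17 log units; within the scatter), and this step does not differ measurably from the earlier instance of the same change: the same change on two cores in this assay, a 1.3-fold higher number (0.10 log units; within the scatter) from compound 1 to compound 2 and a 1.5-fold lower number (0.17 log units; within the scatter) from compound 3 to compound 4, 1.9-fold (0.27 log units) apart, within the scatter of two such steps Ethyl in place of hydrogen on an oxygen on a saturated carbon, carried to the core of compound 2, gave a 3.6-fold lower number from compound 2 to compound 4 (0.55 log units; beyond the scatter), the only new step beyond the scatter, yet it too cannot be told apart from its earlier instance: the same change on two cores in this assay, a 1.9-fold lower number (0.28 log units; within the scatter) from compound 1 to compound 3 and a 3.6-fold lower number (0.55 log units; beyond the scatter) from compound 2 to compound 4, 1.9-fold (0.27 log units) apart, within the scatter of two such steps Across these four compounds, then, each change reads on the second core as it did on the first within the scatter, so no dependence on the core can be seen, but this does not show that the two changes are independent in general, since small steps like these could hide a modest dependence and only two cores are compared for each change.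

The compounds shown leave open how a longer chain than ethyl on that oxygen, or a carboxylic acid in place of the methoxycarbonyl, would read in this assay. They also leave open whether the same transfer would hold for an amine-bearing chain at either place, or in any other cell line.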